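Chlorophenyl placement on the shared core: compound 4

The compounds below may be only part of what the source reports. "The series", "measured", "known", "first", "only" and "open" are said of these compounds alone.

Three compounds on one shared core have numbers in an assay on isolated protein for displacement of a labelled ligand from melanin-concentrating hormone receptor 1 (Homo sapiens); on this read-out lower numbers stand for stronger inhibition and higher numbers for weaker inhibition. Compound 1 `CCCc1cc(N)c2cc(NC(=O)/C=C/c3ccc(Cl)cc3)ccc2n1` gives 6 nM, the lowest of the three. Compound 2 `CCCc1cc(NC2CC2)c2cc(NC(=O)/C=C/c3ccc(C(F)(F)F)cc3)ccc2n1` gives 40 nM, a higher number, beyond the scatter from compound 1. Compound 3 `CCCc1cc(N)c2cc(N(C)C(=O)CCc3ccc(C(F)(F)F)cc3)ccc2n1` gives 1700 nM, the highest of the three and far beyond the scatter from compound 1. Compound 2 and compound 3 each differ from compound 1 in more than one place, so neither gap can be tied to a single change; the two values simply show that both sit well above compound 1.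

Compound 4 `CCCc1cc(N)c2cc(NC(=O)/C=C/c3ccccc3Cl)ccc2n1` differs from compound 1 in one place: 2-chlorophenyl in place of 4-chlorophenyl on a double-bonded chain carbon bound to a double-bonded chain carbon. For the measured compounds named here, no measured pair in this set isolates a move of the chlorine around the ring, so the direction rests on the change itself and on compound 1 as the only anchor. The expectation is a moderate loss, beyond the scatter but far short of the gap seen for compound 3, with the estimated step being a 4.2-fold higher number from compound 1 to compound 4 (0.62 log units; beyond the scatter). Compound 4 is therefore expected at about 25 nM, within a range of 6 nM to 100 nM.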

Compound 4, half-maximal inhibitory concentration: 120 nM
The estimate for compound 4 lay 4.8-fold (0.68 log units) below the measured number; measured number above the stated range.
By their numbers in this assay, from the lowest: compound 1; then compound 2; then compound 4; then compound 3.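

In this assay, for the compounds shown here, this is the first pair that differs in one place, and it shows that the location of the chlorine on the ring matters in its own right: the two compounds have the same atoms, yet 2-chlorophenyl in place of 4-chlorophenyl on a double-bonded chain carbon bound to a double-bonded chain carbon gives a 20-fold higher number from compound 1 to compound 4 (1.30 log units; beyond the scatter). Compound 2 and compound 3 could not show this, as each differs from compound 1 in more than one place, so this is the only gap in the set that can be tied to a single change. Nothing available here bears on why moving the chlorine gives so large a step.

Still open, on these data alone, is whether another group at this place, such as a phenyl ring without chlorine, a methoxyphenyl or a pyridine ring, would stay close to compound 1 or fall as far as compound 4. Also open, as far as these compounds go, is whether the same move would give a step of similar size with a trifluoromethyl group on the ring, or on a core carrying the cyclopropyl amine of compound 2.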